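The source may hold more compounds than are shown below. What is called first, only, known or untested is meant among the compounds shown, and "the series" means these compounds.

Measured compounds:
compound 1, `COc1ccc2nc(C)c(NC(=O)C(=O)Nc3cc(C)cc(C)c3)c(O)c2c1`: > 100000 nM
compound 2, `COc1ccc2nc(C)cc(OCC(=O)Nc3cccc(C)c3)c2c1`: 39800 nM

Two compounds carry values in a toxicity assay on HepG2 cells (Homo sapiens) for inhibition, read by CellTiter-Glo, with a stated time of 48 h; on this read-out lower numbers stand for stronger inhibition and higher numbers for weaker inhibition. Compound 1 reaches only a limit of the assay there, > 100000 nM, so no number is known for it. For the measured compounds named here, compound 2 is the one compound with a number, 39800 nM, and it therefore stands alone among the values shown. Going by the values given here, the one further value, that of compound 1, is a limit; this is the situation summarised by the limit of > 100000 nM in this assay, at which 1 of the 2 values shown sits.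

Compound 3, `COc1ccc2nc(C)cc(OCC(=O)Nc3nccs3)c2c1`, has not been measured. It differs from compound 2 in one place: 1,3-thiazol-2-yl in place of 3-methylphenyl on an amide-type nitrogen. Among the compounds with values here, no step between measured compounds is available to set the size of this change, so the expectation rests on compound 2 alone, whose value is 39800 nM. A move from a six-membered aromatic ring of carbon only to a five-membered aromatic ring with two hetero atoms is not expected to sharpen the toxic effect; if anything a weaker effect seems more likely, though a step within the scatter is also plausible. Compound 3 is estimated at 63000 nM, between 18000 nM and 150000 nM, which corresponds to an expected 1.6-fold higher number from compound 2 to compound 3 (0.20 log units; within the scatter).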

Compound 3, half-maximal inhibitory concentration: > 100000 nM
Compound 3: a limit, no number (the forecaster's own chance of this, stated with the estimate: 35%); at least 1.5-fold (0.20 log units) between middle value and limit.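

In this assay, the change on the amide-type nitrogen gives the only readable step among the compounds shown: 1,3-thiazol-2-yl in place of 3-methylphenyl produces an at least 2.5-fold higher number from compound 2 to compound 3 (0.40 log units; beyond the scatter). This shows that the group on this nitrogen matters for the read-out, something compound 1 could not show, as it differs from compound 2 in more than one place. The step gives only a lower bound and its full size stays unknown, because compound 3 reaches a limit and not a number: the limit of > 100000 nM in this assay, at which 2 of the 3 values shown sit.

The compounds shown leave open whether the step follows from the smaller ring or from its hetero atoms, a question that a pyridinyl group on the same nitrogen would help to separate. Also open, as far as these compounds go, is what the methyl group of 3-methylphenyl contributes, and an unsubstituted phenyl group at this place would address that, while a numerical value for any compound beyond the limit would require a read-out that reaches further.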